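A few compounds are considered here, and "the series" means these few. Any claim that something is new, unique, unknown or untested is made for them only; others in the source may bear on it.

Compound 3 `COc1ccc(-n2ncc(C(=O)Nc3ccc(C(F)(F)F)cc3)c2C)cc1` gives the lowest number of the three in a functional assay with Homo sapiens as the target (a lower number here means a stronger inhibitor, a higher number a weaker inhibitor), at 340 nM. Compound 1 `Cc1c(C(=O)Nc2ccc(C(F)(F)F)cc2)cnn1Cc1ccc(F)cc1` gives 3600 nM in this assay, and compound 2 `Cc1cccc(NC(=O)c2cnn(-c3ccc(F)cc3)c2C)c1` gives 5700 nM. Compound 4 `Cc1c(C(=O)Nc2ccc(C(F)(F)F)cc2)cnn1-c1cccc(F)c1` differs from compound 3 by 3-fluorophenyl in place of 4-methoxyphenyl on an aromatic nitrogen. Within the data shown here, the one measured step, an 11-fold lower number from compound 1 to compound 3 (1.02 log units; beyond the scatter), concerns a different pair of groups at the same place, so it bears only loosely on this change; compound 2, which carries a fluorine-bearing aryl on that nitrogen but a different amide-side aryl, gives a much higher number than compound 3 without a single-step link. Compound 4 is therefore expected to give a moderately higher number, a 2.9-fold higher number from compound 3 to compound 4 (0.47 log units; beyond the scatter), with an estimate of 1000 nM and a range of 300 nM to 3500 nM.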

Compound 4, half-maximal inhibitory concentration: 3100 nM
Estimate against measurement, compound 4: 3.1-fold (0.49 log units) below; the range from low to high includes it.
By their numbers in this assay, from the lowest: compound 3; then compounds 4, 1 and 2 (each within the scatter of the next).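

Changing the group on the aromatic nitrogen from 4-methoxyphenyl to 3-fluorophenyl gives a large loss (a 9.1-fold higher number from compound 3 to compound 4 (0.96 log units; beyond the scatter)), so an aryl group directly on that nitrogen does not by itself secure the low number of compound 3. Compound 4 and compound 1 cannot be told apart (a 1.2-fold lower number from compound 1 to compound 4 (0.06 log units; within the scatter)), so 3-fluorophenyl and 4-fluorobenzyl perform alike here. Nothing measured accounts for these differences.

From the compounds shown here alone, it remains open whether 3-methoxyphenyl or 4-fluorophenyl on this core would track compound 3 or compound 4. Going by these compounds, it also remains open whether an ethoxy or dimethylamino group could replace the methoxy group of compound 3.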